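Methyl in Place of Fluoro: What to Expect for Compound 3

The source may report more compounds than this note shows. Statements on the series, on what has been measured and on what is new or still open speak of the compounds shown alone.

Compound 1, `O=C(Nc1nc2ccccc2s1)c1cn(-c2ccccc2)nc1-c1ccc(Cl)cc1`, gave 11500 nM in a functional assay on U-87MG ATCC cells for cytotoxicity against U-87 MG (Homo sapiens), read by MTT assay, with a stated time of 72 h; on this read-out higher numbers stand for weaker inhibition and lower numbers for stronger inhibition.
Compound 2, `O=C(Nc1nc2ccc(F)cc2s1)c1cn(-c2ccccc2)nc1-c1ccc(Cl)cc1`, gave 7770 nM in this assay.

Of these two numbers compound 2 holds the lower one, but the step of a 1.5-fold lower number from compound 1 to compound 2 (0.17 log units; within the scatter) lies within the scatter, so the two compounds cannot be set in order on this read-out. Compound 3, `Cc1ccc2nc(NC(=O)c3cn(-c4ccccc4)nc3-c3ccc(Cl)cc3)sc2c1`, has not been measured. It differs from compound 2 by methyl in place of fluoro on an aromatic carbon. Among the measured compounds shown here, the only measured step at this position is a 1.5-fold lower number from compound 1 to compound 2 (0.17 log units; within the scatter), which was small, and there is no measured pair in which methyl replaces fluoro. Nothing beyond the scatter is therefore expected in this assay from compound 2 to compound 3. Compound 3 is estimated at about 8000 nM, within a range of 3500 nM to 18000 nM. The expected step of a 1.0-fold higher number from compound 2 to compound 3 (0.01 log units; within the scatter) is thus one that stays inside the scatter.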

Compound 3, half-maximal inhibitory concentration: 33200 nM
Compound 3: middle estimate off by 4.2-fold (0.62 log units), on the low side; the whole stated range lies below it.
By their numbers in this assay, from the lowest: compounds 2 and 1 (each within the scatter of the next); then compound 3.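

In this assay the position proves sensitive to what it carries: methyl in place of fluoro gives a 4.3-fold higher number from compound 2 to compound 3 (0.63 log units; beyond the scatter) and methyl in place of hydrogen gives a 2.9-fold higher number from compound 1 to compound 3 (0.46 log units; beyond the scatter). The earlier pair had shown only a step within the scatter, so the first readable change at this position is the arrival of methyl, which leaves compound 3 the weakest of the three. Both steps are modest, and they rest on compound 3 alone, so the shift cannot yet be called a pattern.

On these data alone, whether a methoxy group, a chlorine or an amine at this position would stay level with compound 1 and compound 2 or go the way of compound 3 remains open. Nothing available explains why methyl parts from fluoro and hydrogen here.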